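The compounds below may be only part of what the source reports. "The series", "measured", "known", "first", "only" and "open" are said of these compounds alone.

Measured compounds in a functional assay on HeLa cells (Homo sapiens) for inhibition, read by MTT assay, with a stated time of 48 h; on this read-out lower numbers stand for stronger inhibition and higher numbers for weaker inhibition:
compound 1, `COc1ccc2c(=O)c(/C=C/C(=O)Nc3cccc(C)c3)coc2c1`: > 100000 nM
compound 2, `COc1ccc2c(=O)c(/C=C/C(=O)Nc3cccc(Cl)c3)coc2c1`: 11900 nM
compound 3, `COc1ccc(NC(=O)/C=C/c2coc3cc(OC)ccc3c2=O)cc1`: 13000 nM

The value given for compound 1 is a limit of the assay and not a number, as stated in the limit of > 100000 nM in this assay, at which 1 of the 3 values shown sits. Among the two real numbers, compound 3 holds the higher one; its nearest neighbour is compound 2, and the gap between them, a 1.1-fold higher number from compound 2 to compound 3 (0.04 log units; within the scatter), is within the scatter. Against compound 1 the change is an at least 7.6-fold lower number from compound 1 to compound 3 (0.88 log units; beyond the scatter), beyond the scatter, so an exchange of the group on the amide nitrogen can matter in this assay.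

Compound 4, `COc1ccc2c(=O)c(/C=C/C(=O)Nc3ccccc3OC)coc2c1`, differs from compound 3 as 2-methoxyphenyl in place of 4-methoxyphenyl on an amide-type nitrogen. Going by the values given here, no measured step moves the methoxy group around the ring on the amide nitrogen; the closest measured exchange of that ring, a 1.1-fold higher number from compound 2 to compound 3 (0.04 log units; within the scatter), stayed within the scatter. On that basis a step within the scatter is expected, no change at the digits printed from compound 3 to compound 4 (within the scatter). Compound 4 is therefore estimated at 13000 nM, with a range from 4000 nM to 45000 nM.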

Compound 4, half-maximal inhibitory concentration: > 100000 nM
Compound 4: no number, only a limit (the forecaster's own chance of this, stated with the estimate: 15%); at least 7.6-fold (0.88 log units) between middle value and limit.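

With the same atoms joined differently, 2-methoxyphenyl in place of 4-methoxyphenyl on an amide-type nitrogen gives an at least 7.6-fold higher number from compound 3 to compound 4 (0.88 log units; beyond the scatter) in this assay, so moving the methoxy group alone can produce a step beyond the scatter. Against the 3-chlorophenyl amide there is an at least 8.4-fold higher number from compound 2 to compound 4 (0.92 log units; beyond the scatter), whereas the 4-methoxyphenyl amide stayed within the scatter of that compound, so the exchange of this ring is not neutral for every methoxyphenyl group. Compound 4 has a limit of the assay and not a number, and the step to compound 1 cannot be read, as both compounds stand at the same limit: the limit of > 100000 nM in this assay, at which 2 of the 4 values shown sit.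

As far as these compounds go, how far compound 4 lies past that limit remains open, and with it the full size of these steps. Also open, from the compounds shown here alone, is whether a dimethylamino group or a carboxylic acid in place of the methoxy group would follow compound 3 or compound 4.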